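The source may report more compounds than this note shows. Statements on the series, on what has been measured and on what is new or still open speak of the compounds shown alone.

Working notes on the series. Compound 1 `COc1ccc(/C=C2\CN(Cc3cn(Cc4cccc(Cl)c4)nn3)C/C(=C\c3ccc(OC)cc3)C2=O)cc1` gives 56600 nM in a functional assay on 4T1 cells (Mus musculus) for cytotoxicity, read by MTT assay, with a stated time of 24 h (on this read-out lower numbers stand for stronger inhibition and higher numbers for weaker inhibition), the highest of the two numbers recorded so far. Compound 2 `Cc1ccc(/C=C2\CN(Cc3cn(Cc4ccccc4F)nn3)C/C(=C\c3ccc(C)cc3)C2=O)cc1` differs from compound 1 in more than one place. In this assay compound 2 gives 18000 nM, a lower number. For the measured compounds named here, the gap between compound 1 and compound 2 lies beyond the scatter, and no single-change step connects these two compounds.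

Compound 3 `COc1ccc(/C=C2\CN(Cc3cn(Cc4ccccc4F)nn3)C/C(=C\c3ccc(OC)cc3)C2=O)cc1` has not yet been measured. It differs from compound 1 by 2-fluorophenyl in place of 3-chlorophenyl on a saturated chain carbon bound to an aromatic nitrogen. Compound 2 also carries the 2-fluorophenyl at this place, but its further difference from compound 1 leaves the share of each change open, so the reading of compound 2 is only a weak pointer.

The step from compound 1 to compound 3 is expected to be a modest lowering, estimated at a 1.6-fold lower number from compound 1 to compound 3 (0.21 log units; within the scatter), at the edge of the scatter. For compound 3 the expected value in this assay is 35000 nM, with a range from 15000 nM to 80000 nM.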

Compound 3, half-maximal inhibitory concentration: 39400 nM
Beside the measured number, compound 3's estimate is 1.1-fold (0.05 log units) below it; measured number inside the range.
By their numbers in this assay, from the lowest: compound 2; then compounds 3 and 1 (each within the scatter of the next).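

For the compounds shown here, putting 2-fluorophenyl in place of 3-chlorophenyl on a saturated chain carbon bound to an aromatic nitrogen gives a 1.4-fold lower number from compound 1 to compound 3 (0.16 log units; within the scatter) in this assay, the first reading of this change alone. At this position, with the rest of the structure held, the two groups cannot be told apart in this read-out, and the reading no longer rests on compound 2, whose further difference left the share of each change open. No measurement at hand bears on the reason for this result.

The compounds shown leave open whether a group of another kind at this place, such as a carboxylic acid or an amine on a longer chain, would move the number beyond the scatter. They also leave open whether the same change reads alike with the other groups that compound 2 carries on the core.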